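Swapping the pyridine for a methoxy-methylphenyl group

A few compounds are considered here, and "the series" means these few. Any claim that something is new, unique, unknown or untested is made for them only; others in the source may bear on it.

Measured so far:
compound 1 `COc1ccccc1N1CCN(CCCNc2ncccc2C(=O)NC(C)(C)C)CC1` gives 1.26 nM
compound 2 `CN(C)C(=O)c1cccnc1NCCCN1CCN(c2ccccc2OCC2CC2)CC1` gives 0.159 nM
compound 3 `Cc1cnccc1N1CCN(CCCNc2ncccc2C(=O)N(C)C)CC1` gives 200 nM

In a functional assay for antagonist activity at Alpha-1A adrenergic receptor (Oryctolagus cuniculus) (a lower number here means tighter binding, a higher number weaker binding), compound 3 has the highest number of the three measured compounds; compound 1 lies far below it and compound 2 further still, both gaps beyond the scatter. Compound 4 `COc1cc(C)ccc1N1CCN(CCCNc2ncccc2C(=O)N(C)C)CC1` is not yet measured. It differs from compound 3 in one place: 2-methoxy-4-methylphenyl in place of 3-methylpyridin-4-yl on an amine nitrogen in a ring. Compounds 1 and 2, which both carry an aromatic ring of carbon only with an alkoxy group on the amine nitrogen in a ring, sit far lower than compound 3, so a large drop in this assay is expected from compound 3 to compound 4, a 250-fold lower number from compound 3 to compound 4 (2.40 log units; beyond the scatter). Compound 4 is therefore expected to reach about 0.8 nM, within a range from 0.2 nM to 4 nM.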

Compound 4, dissociation constant: 0.794 nM
Compound 4: the middle estimate sits 1.0-fold (0.00 log units) above what was measured; measured number inside the range.
By their numbers in this assay, from the lowest: compound 2; then compounds 4 and 1 (each within the scatter of the next); then compound 3.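

In this assay, among these compounds, the single change of 2-methoxy-4-methylphenyl in place of 3-methylpyridin-4-yl gives a 250-fold lower number from compound 3 to compound 4 (2.40 log units; beyond the scatter). Among the compounds shown here, the earlier compounds differ from one another in more than one place, so this is the first direct sign that the group on this amine nitrogen alone can shift the number by a large amount. Nothing available explains the size of this step.

On these data alone, the change swaps the ring and its substituents together, so the contribution of each part remains open. A plain phenyl group or a methoxy-bearing pyridine ring at this position could help separate them.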